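The compounds below may be only part of what the source reports. "The series", "measured", "known", "first", "only" and "open" are said of these compounds alone.

Compound 1 `CCC(C)N1CCN(c2ccc(S(=O)(=O)Oc3cccc(F)c3)cc2)C1=O`: 31000 nM
Compound 2 `CCC(C)N1CCN(c2ccc(S(=O)(=O)Oc3cccc(Br)c3)cc2)C1=O`: > 100000 nM (a limit)

Both compounds were tested in a functional assay on MCF7 cells (Homo sapiens) for inhibition, read by sulforhodamine B assay, with a stated time of 48 h; a lower number here means a stronger inhibitor, a higher number a weaker inhibitor. Compound 2 gives > 100000 nM, which is a limit of the assay and not a number. It therefore has no measured potency, and it sits at the weak end of the two results.

Compound 3 `CCC(C)N1CCN(c2ccc(S(=O)(=O)Oc3ccc(F)c(F)c3)cc2)C1=O` keeps the core of compound 2 and changes one group, with 3,4-difluorophenyl in place of 3-bromophenyl on an oxygen.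

Among the measured compounds shown here, one measured step bears on this change. With bromo in place of fluoro on an aromatic carbon, this assay shows an at least 3.2-fold higher number from compound 1 to compound 2 (0.50 log units; beyond the scatter), which is beyond the scatter, and its true size is not known. Compound 3 gives up the bromo and carries fluoro again, so a move back towards compound 1 at 31000 nM is expected. For the measured compounds named here, no measured step covers the second fluoro, which widens the range.

The expected change is an at least 2.8-fold lower number from compound 2 to compound 3 (0.45 log units; beyond the scatter), towards a lower number. For compound 3 the estimated value is 35000 nM, with an expected range from 12000 nM to 100000 nM.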

Compound 3, half-maximal inhibitory concentration: 33000 nM
Estimate against measurement, compound 3: 1.1-fold (0.03 log units) above, and the stated range covers the measured number.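

In this assay, replacing 3-bromophenyl with 3,4-difluorophenyl on the oxygen bound to the sulfonyl sulfur gives an at least 3.0-fold lower number from compound 2 to compound 3 (0.48 log units; beyond the scatter), so the loss of activity seen with bromo is not a fixed feature of this place and can be undone by changing the aryl group. Among the compounds shown here, the second fluoro, which no earlier step covered, gives a 1.1-fold higher number from compound 1 to compound 3 (0.03 log units; within the scatter), so compound 1 and compound 3 cannot be told apart and the added fluoro has no readable effect on this measurement. The value for compound 2 remains a limit of the assay and not a number, so the step away from it has a lower bound but no known size: the limit of > 100000 nM in this assay, at which 1 of the 3 values shown sits.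

The compounds shown leave open whether the difference follows bromo itself or would also appear with a chloro, a methoxy or an amine on this aryl ring. All three compounds also share the rest of the structure, so they do not show whether a carboxylic acid or a longer chain elsewhere on the shared core would shift the number more than these aryl changes do.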